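The source may hold more compounds than are shown below. What is called first, only, known or untested is meant among the compounds shown, and "the series" means these compounds.

Of the compounds shown here, two of a shared core have been measured. In an assay on HEK293 cells for displacement of a labelled ligand from adenosine receptor A2b (Homo sapiens), read by scintillation counting, with a stated time of 30 min, tested at 10 uM (a lower number here means less inhibition, a higher number more inhibition at the concentration tested (going by the name of the read-out)), compound 1 `N=c1oc2ccc(Br)cc2cc1C(=O)NC1CCCCC1` gives 10%, and in this assay compound 2 `O=C(O)CNC(=O)c1cc2ccccc2oc1=O` gives 9%; the two values sit within the scatter of each other, so neither can be set above the other. Compound 3 `N=c1oc2ccc(Br)cc2cc1C(=O)NCCCO` differs from compound 1 by the change (3-hydroxypropyl in place of cyclohexyl on an amide-type nitrogen). Among the measured compounds shown here, no measured pair shows this change, so the expected step of no change at the digits printed from compound 1 to compound 3 (within the scatter) is estimated as none beyond the scatter. Compound 3 is therefore expected to give about 10%, within 0% to 30%.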

Compound 3, a percentage reported as inhibition, at one concentration (the size of the read-out at that concentration, not a potency): 25%
Compound 3: middle estimate off by 15 percentage points, on the low side, and the stated range covers the measured number.
By their numbers in this assay, from the lowest: compounds 2 and 1 (each within the scatter of the next); then compound 3.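

Among the compounds shown here, compound 1 and compound 2 differ in more than one place, so this is the first change that can be read at a single position. In this assay, 3-hydroxypropyl in place of cyclohexyl on the amide-type nitrogen gives a number 15 percentage points higher from compound 1 to compound 3 (beyond the scatter), so the group at this position can shift the reading. Nothing available explains the shift.

The compounds shown leave open whether the gain follows the hydroxyl or the loss of the ring; a plain propyl group would separate the two. As far as these compounds go, how an amine or a carboxylic acid at the chain end, or a longer chain, would read also remains open.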